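The source may hold more compounds than are shown below. What is called first, only, known or untested is meant among the compounds shown, and "the series" means these compounds.

Compound 1, with the structure `N#Cc1ccc(NC(=O)c2ccc3cccnc3c2O)cc1`, is the reference point of this small set. In a functional assay on NALM-6 cells (Homo sapiens) for cytotoxicity, read by luminescence and CellTiter-Glo, with a stated time of 3 days (a lower number here means a stronger inhibitor, a higher number a weaker inhibitor), compound 1 gives 130 nM. Compound 2, `O=C(Nc1ccc(Cl)cc1)c1ccc2cccnc2c1O`, carries chloro in place of cyano on an aromatic carbon on the shared core, and compound 2 gives 380 nM, so that a 2.9-fold higher number from compound 1 to compound 2 (0.47 log units; beyond the scatter). Compound 3, `N#Cc1ccc(NC(=O)c2ccc3cccnc3c2O)c(C#N)c1`, differs from compound 1 by cyano in place of hydrogen on an aromatic carbon; compound 3 gives 350 nM, and a 2.7-fold higher number from compound 1 to compound 3 (0.43 log units; beyond the scatter).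

Compound 4, `N#Cc1ccc(NC(=O)c2ccc3cccnc3c2O)c(Cl)c1`, is not yet measured. It differs from compound 3 by chloro in place of cyano on an aromatic carbon. Going by the values given here, this is the same kind of change as the one from compound 1 to compound 2, though the surroundings differ: in compound 2 the chloro sits para to a large group, whereas in compound 4 it sits ortho to a large group and meta to a cyano group. Resting on the earlier step, the expected step is a 2.4-fold higher number from compound 3 to compound 4 (0.39 log units; beyond the scatter), set beside a 2.9-fold higher number from compound 1 to compound 2 (0.47 log units; beyond the scatter). The place is not the same, and the range is set wider. Compound 4 is expected to give about 850 nM in this assay, estimated between 300 nM and 2500 nM.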

Compound 4, half-maximal inhibitory concentration: 420 nM
Estimate against measurement, compound 4: 2.0-fold (0.31 log units) above; the measured number falls inside the stated range.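

In this assay, chloro in place of cyano on an aromatic carbon gives a 1.2-fold higher number from compound 3 to compound 4 (0.08 log units; within the scatter), while chloro in place of hydrogen on the core of compound 1 gives a 3.2-fold higher number from compound 1 to compound 4 (0.51 log units; beyond the scatter). Set beside the earlier exchange of cyano for chloro, the new step gives no ground to say that the change behaves differently on the two cores: the same change on two cores in this assay, a 2.9-fold higher number (0.47 log units; beyond the scatter) from compound 1 to compound 2 and a 1.2-fold higher number (0.08 log units; within the scatter) from compound 3 to compound 4, 2.4-fold (0.39 log units) apart, within the scatter of two such steps. Going by these compounds alone, this does not show that the change carries over unaltered, since only two pairs are available, the group sits in a different place in each, and only the earlier step lies beyond the scatter.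

The compounds shown carry only hydrogen, cyano and chloro at the varied places on this six-membered aromatic ring, so it remains open how a methoxy group, an amine or a carboxylic acid would read there. On these data alone, whether the exchange of cyano for chloro would give similar steps on further cores also remains open.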